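This account rests on a few compounds, and the source may have more. Where it says the series, first, only, none or still open, it means among the compounds named here.

Measured so far:
Compound 1, `COc1cc(C2=NO[C@]3(C2)C(=O)O[C@@H]2[C@H]3CC[C@H](C)[C@]3(O)C=CC(=O)[C@@]23C)ccc1O`, gives 0.75 in a physicochemical assay for lipophilicity; on this read-out lower numbers stand for lower lipophilicity and higher numbers for higher lipophilicity.
Compound 2, `C[C@H]1CC[C@@H]2[C@@H](OC(=O)[C@]23CC(c2ccc(Br)cc2)N(c2ccccc2)O3)[C@]2(C)C(=O)C=C[C@@]12O`, gives 4.

Compound 2 stands highest of the two numbers in this assay; compound 1 lies lower by a margin beyond the usual scatter. Compound 3, `C[C@H]1CC[C@@H]2[C@@H](OC(=O)[C@]23CC(c2ccccc2F)N(c2ccccc2)O3)[C@]2(C)C(=O)C=C[C@@]12O`, is not yet measured. It differs from compound 2 in one place: 2-fluorophenyl in place of 4-bromophenyl on a saturated ring carbon. Among the compounds with values here, with no measured step of this kind to go by, the expectation rests on the change alone: a moderate drop is expected, beyond the scatter. The step from compound 2 to compound 3 is estimated at a number 0.70 log units lower from compound 2 to compound 3 (beyond the scatter). Compound 3 is expected to give 3.3, within 2.9 to 3.7.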

Compound 3, partition coefficient: 3.35
For compound 3 the middle estimate is 0.05 log units below the measured one, and the stated range covers the measured number.
By their numbers in this assay, from the lowest: compound 1; then compound 3; then compound 2.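

In this assay this saturated ring carbon now has its first measured step: putting 2-fluorophenyl in place of 4-bromophenyl gives a number 0.65 log units lower from compound 2 to compound 3 (beyond the scatter) and shows that the read-out responds to a change of aryl group here. The swap alters the halogen and its place on the ring together, and this single step cannot separate the two. Nothing measured here bears on the reason for the drop. Still open, on these data alone, is how this carbon would read with an unsubstituted phenyl, an amine or a carboxylic acid.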